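An Ester-to-Ether Swap at a Weakly Active Starting Point

The source may report more compounds than this note shows. Statements on the series, on what has been measured and on what is new or still open speak of the compounds shown alone.

Compound 1 `CC(C)=CC[C@@H](OC(=O)C1CCCCO1)C1=CC(=O)c2c(O)ccc(O)c2C1=O` is tested in a functional assay on HeLa cells (Homo sapiens) for cytotoxicity, read by MTT assay; on this read-out lower numbers stand for stronger inhibition and higher numbers for weaker inhibition. Compound 1 gives only a limit of the assay there, > 100000 nM, so its own position on the scale is not a fixed number. Two measured relatives carry other ester groups: compound 2 `CCCC(CC(=O)O[C@H](CC=C(C)C)C1=CC(=O)c2c(O)ccc(O)c2C1=O)OC(C)=O` gives 51200 nM and compound 3 `CCCCC(CC(=O)O[C@H](CC=C(C)C)C1=CC(=O)c2c(O)ccc(O)c2C1=O)OC(C)=O` gives 73500 nM. The measured steps are an at least 1.9-fold lower number from compound 1 to compound 2 (0.29 log units; that floor lies within the scatter), an at least 1.3-fold lower number from compound 1 to compound 3 (0.13 log units; that floor lies within the scatter) and a 1.4-fold higher number from compound 2 to compound 3 (0.16 log units; within the scatter), all small, in keeping with the limit of > 100000 nM in this assay, at which 1 of the 3 values shown sits. Compound 4 `CC(=O)OC(C)CO[C@H](CC=C(C)C)C1=CC(=O)c2c(O)ccc(O)c2C1=O` differs from compound 1 by 2-acetoxypropyl in place of (oxan-2-yl)carbonyl on an oxygen on a saturated carbon, so the carbonyl leaves together with the ring. Going by the values given here, no measured step covers such a change, and no shift beyond the scatter is expected. The estimate for compound 4 is 80000 nM, in a range of 30000 nM to 250000 nM, which is expected to mean an at least 1.2-fold lower number from compound 1 to compound 4 (0.09 log units; that floor lies within the scatter).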

Compound 4, half-maximal inhibitory concentration: 40100 nM
The estimate for compound 4 lay 2.0-fold (0.30 log units) above the measured number; the range from low to high includes it.
By their numbers in this assay, from the lowest: compounds 4, 2 and 3 (each within the scatter of the next). At a limit, above all of these: compound 1.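

In this assay, 2-acetoxypropyl in place of (oxan-2-yl)carbonyl gives an at least 2.4-fold lower number from compound 1 to compound 4 (0.39 log units; beyond the scatter). Going by these compounds alone, the floors of the steps to compound 2 and compound 3 stayed within the scatter, so this is the first sign that this oxygen can lose both the carbonyl and the ring while a measurable number remains. The true size of the step is unknown, since one end of it is only a limit: the limit of > 100000 nM in this assay, at which 1 of the 4 values shown sits.

Going by these compounds, whether the acetoxy group itself matters here remains open. So does whether an amine, a carboxylic acid or a longer chain in its place would move the number further.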